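The source may hold more compounds than are shown below. What is called first, only, known or untested is meant among the compounds shown, and "the series" means these compounds.

Compounds measured so far:
Compound 1 `C=C1CC[C@H]2[C@@](C)(CC[C@@H](OC(=O)c3cccnc3)[C@@]2(C)NC=O)[C@@H]1/C=C/C1=CCOC1=O` — > 50000 nM
Compound 2 `C=C1CC[C@H]2[C@@](C)(CC[C@@H](OC(=O)c3ccc([N+](=O)[O-])cc3)[C@@]2(C)NC=O)[C@@H]1/C=C/C1=CCOC1=O` — > 50000 nM

Both values are limits of an assay for inhibition of hexokinase-2 (Homo sapiens), read by coupled enzyme assay, with a stated time of 10 min, in the presence of a further agent that is not named here (a lower number here means a stronger inhibitor, a higher number a weaker inhibitor), not numbers. In this assay compound 1 reaches only the limit > 50000 nM. In this assay compound 2 likewise reaches only the limit > 50000 nM. Going by the values given here, the step from compound 1 to compound 2 is a step that the two limits leave unreadable from compound 1 to compound 2, which the limit of > 50000 nM in this assay, at which 2 of the 2 values shown sit, leaves unreadable; it is the only measured step, and it does not touch the ring entering here.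

Compound 3 `C=C1CC[C@H]2[C@@](C)(CC[C@@H](OC(=O)[C@H]3CCCN3)[C@@]2(C)NC=O)[C@@H]1/C=C/C1=CCOC1=O` differs from compound 2 by pyrrolidin-2-yl in place of 4-nitrophenyl on a carbonyl carbon. Among the compounds with values here, no measured step bears on this change, so compound 3 is expected to show a step that the limit leaves unreadable from compound 2 to compound 3. The estimate for compound 3 is therefore 60000 nM, within 12000 nM to 300000 nM, most likely again a limit.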

Compound 3, half-maximal inhibitory concentration: 26100 nM
Estimate against measurement, compound 3: 2.3-fold (0.36 log units) above; low and high end bracket the measured number.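

With pyrrolidin-2-yl on this carbonyl carbon, compound 3 is the only compound shown to give a number rather than a limit in this assay, so this position first becomes readable here. The change gives an at least 1.9-fold lower number from compound 2 to compound 3 (0.28 log units; that floor lies within the scatter), and an at least 1.9-fold lower number from compound 1 to compound 3 (0.28 log units; that floor lies within the scatter). Both are floors only, and the step between the two aromatic groups cannot be read: the limit of > 50000 nM in this assay, at which 2 of the 3 values shown sit.

As far as these compounds go, whether the number depends on the ring nitrogen, the amine hydrogen or the defined stereocentre stays open. So does whether an open-chain amine or a carboxylic acid on this carbonyl carbon would give a similar number.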